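The source may report more compounds than this note shows. Statements on the series, on what has been measured and on what is new or still open speak of the compounds shown alone.

In an ADME assay on MT4 cells (Homo sapiens) for cytotoxicity, read by MTT assay, with a stated time of 4 days (a higher number here means that more compound is tolerated, a lower number that less compound is tolerated), all three measured compounds sit at or near the top of the tested range. Compound 1 `COc1c(Oc2ccnc(Nc3ccc(C#N)cc3)n2)ccc2cc(C#N)ccc12` reaches only a limit of the assay, > 211000 nM. Compound 3 `Cc1cnc(Nc2ccc(C#N)cc2)nc1Oc1ccc2cc(C#N)ccc2c1` likewise gives only a limit, > 331000 nM. Compound 2 `N#Cc1ccc(Nc2nccc(Oc3ccc4cc(C#N)ccc4c3Cl)n2)cc1` gives a number, 269000 nM. Among the compounds with values here, the only measured step, a step that the limit leaves unreadable from compound 1 to compound 2, has no readable size, compound 1 standing at a limit.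

Compound 4 `N#Cc1ccc(Nc2nccc(Oc3ccc4cc(C#N)ccc4c3)n2)cc1` differs from compound 3 by hydrogen in place of methyl on an aromatic carbon. Within the data shown here, no measured step tests this change, so there is no basis for expecting a shift beyond the scatter. Compound 4 is therefore expected to remain about as well tolerated as compound 3, the estimated step being an at least 1.1-fold lower number from compound 3 to compound 4 (0.04 log units; that floor lies within the scatter). The estimate for compound 4 is 300000 nM, ranging from 150000 nM to 600000 nM, and quite possibly again only a limit.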

Compound 4, half-maximal cytotoxic concentration: > 68800 nM
Compound 4: a limit, no number; the forecaster's own chance of this, stated with the estimate: 60%; the middle value lies beyond the limit too.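

In this assay compound 4 gives only a limit, > 68800 nM. Within the data shown here, no step from compound 1, compound 2 or compound 3 to compound 4 can be read. The compounds shown leave open whether swapping methyl, chloro or methoxy for hydrogen changes how much compound is tolerated.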